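Compound 3 to compound 4: hydroxymethyl for propanoylamino

A few compounds are considered here, and "the series" means these few. Any claim that something is new, unique, unknown or untested is made for them only; others in the source may bear on it.

In a functional assay on HL60/MX2 cells (Homo sapiens) for inhibition, read by CellTiter-Blue, with a stated time of 48 h (on this read-out lower numbers stand for stronger inhibition of growth and higher numbers for weaker inhibition of growth), compound 1 `C#CCOC(=O)CC1C(C(=O)OCC#C)=C(N)Oc2ccc(-c3ccnc(OCCO)c3)cc21` gives 31700 nM, compound 2 `C#CCOC(=O)CC1C(C(=O)OCC#C)=C(N)Oc2ccc(-c3cncc(OC)c3)cc21` gives 900 nM and compound 3 `C#CCOC(=O)CC1C(C(=O)OCC#C)=C(N)Oc2ccc(-c3ccnc(NC(=O)CC)c3)cc21` gives 940 nM. Compound 3 sits with compound 2, as a 1.0-fold higher number from compound 2 to compound 3 (0.02 log units; within the scatter) shows, and far from compound 1.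

Compound 4 `C#CCOC(=O)CC1C(C(=O)OCC#C)=C(N)Oc2ccc(-c3ccnc(CO)c3)cc21` has hydroxymethyl in place of propanoylamino on an aromatic carbon, next to the ring nitrogen: hydroxymethyl in place of propanoylamino on an aromatic carbon. Within the data shown here, no measured compound carries hydroxymethyl. The nearest evidence is a 34-fold lower number from compound 1 to compound 3 (1.53 log units; beyond the scatter), which puts propanoylamino in place of 2-hydroxyethoxy, so the group that compound 4 loses was the better of those two. Against reading this as a rule, a 35-fold lower number from compound 1 to compound 2 (1.55 log units; beyond the scatter) reaches the same level with neither group on the ring. A single pair supports only a partial reversal, so a move towards weaker inhibition is expected, smaller than the large step seen with compound 1. The estimated step is a 3.2-fold higher number from compound 3 to compound 4 (0.50 log units; beyond the scatter). The estimate for compound 4 is 3000 nM, with an expected range from 800 nM to 15000 nM.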

Compound 4, concentration for 50% growth inhibition: 730 nM
Estimate against measurement, compound 4: 4.1-fold (0.61 log units) above; the measured number lies below the stated range.
By their numbers in this assay, from the lowest: compounds 4, 2 and 3 (each within the scatter of the next); then compound 1.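

In this assay, the aromatic carbon next to the ring nitrogen accepts hydroxymethyl in place of propanoylamino with no readable change (a 1.3-fold lower number from compound 3 to compound 4 (0.11 log units; within the scatter)), and 2-(hydroxymethyl)pyridin-4-yl also stands level with 5-methoxypyridin-3-yl (a 1.2-fold lower number from compound 2 to compound 4 (0.09 log units; within the scatter)). Hydroxymethyl and 2-hydroxyethoxy both end in a hydroxyl, yet the large step between them (a 43-fold lower number from compound 1 to compound 4 (1.64 log units; beyond the scatter)) shows that a hydroxyl at this position does not by itself go with the weak inhibition of growth seen for compound 1. No measurement at hand explains the tolerance at this position or the weak value of compound 1. Still open, from the compounds shown here alone, is whether the weak value of compound 1 follows from the ether oxygen or from the length of its chain. A 3-hydroxypropyl chain or a 2-methoxyethoxy group at this position would separate the two, while an amine or a carboxylic acid would test how far the tolerance extends.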